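Moving one fluorine on the least stable compound

This account rests on a few compounds, and the source may have more. Where it says the series, first, only, none or still open, it means among the compounds named here.

Compound 1 `Cc1nc(-c2ccccc2F)c(C(=O)N2CCN(c3cc(Cl)cc(Cl)c3)CC2)o1`: 82.3%
Compound 2 `COc1cc(OC)cc(N2CCN(C(=O)c3oc(C)nc3-c3ccccc3F)CC2)c1`: 15%
Compound 3 `Cc1cc(C)cc(N2CCN(C(=O)c3oc(C)nc3-c3ccccc3)CC2)c1`: 25.6%

In an ADME assay (liver) for metabolic stability, with Liver microsome (Homo sapiens) as the target, read by LC-MS, using microsomes, with a stated time of 1 h, tested at 5 uM (on this read-out lower numbers stand for a less stable compound and higher numbers for a more stable compound), compound 2 stands lowest of the three at 15%. The nearest value belongs to compound 3 at 25.6%, and the furthest to compound 1 at 82.3%.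

Compound 4 `COc1cc(OC)cc(N2CCN(C(=O)c3oc(C)nc3-c3cccc(F)c3)CC2)c1` has the same atoms as compound 2, joined differently: 3-fluorophenyl in place of 2-fluorophenyl on an aromatic carbon. In short, the fluorine sits elsewhere on the phenyl group, giving 3-fluorophenyl in place of 2-fluorophenyl on an aromatic carbon.

Going by the values given here, only one measured step bears on this, and only loosely: a number 67.3 percentage points lower from compound 1 to compound 2 (beyond the scatter). That step is large, but it lies on an amine nitrogen in a ring, not on the aromatic carbon where the new change falls. Among the compounds with values here, no measured step moves the fluorine, so the data point in neither direction, and no shift beyond the scatter is expected. The estimated change is a number 1 percentage points higher from compound 2 to compound 4 (within the scatter).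

For compound 4 the estimated value is 16%, with an expected range from 6% to 32%.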

Compound 4, percent of the compound remaining: 11.3%
The estimate for compound 4 lay 4.7 percentage points above the measured number; low and high end bracket the measured number.
By their numbers in this assay, from the lowest: compounds 4 and 2 (each within the scatter of the next); then compound 3; then compound 1.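

In this assay, putting 3-fluorophenyl in place of 2-fluorophenyl gives a number 3.7 percentage points lower from compound 2 to compound 4 (within the scatter) and so leaves the two placements of the fluorine indistinguishable on this read-out. Going by these compounds alone, the earlier step concerned the group on the amine nitrogen in a ring, whereas this is the first measured change on the aromatic carbon, and with the 3,5-dimethoxyphenyl group in place, moving the fluorine does not separate the two compounds. Nothing measured here offers a reason for this result.

As far as these compounds go, it remains open whether a group of another kind on this aromatic carbon, such as a pyridine ring or a phenyl carrying a nitrile, would shift the number. Also open, from the compounds shown here alone, is whether the same fluorine move would give a similar result with the 3,5-dichlorophenyl group of compound 1.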